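Adding a Pyrazolylamino Group to a Small Kinase Inhibitor

A few compounds are considered here, and "the series" means these few. Any claim that something is new, unique, unknown or untested is made for them only; others in the source may bear on it.

Measured compounds:
Compound 1 `Cc1nn(C2COC2)cc1Nc1nc(N)c2c(C#N)c(N3CCC[C@H]3C)n(C)c2n1`: 38 nM
Compound 2 `C[C@@H]1CCCN1c1c(C#N)c2c(N)ncnc2n1C`: 15 nM

Of the compounds shown here, two have been measured in an assay on isolated protein for inhibition of Leucine-rich repeat serine/threonine-protein kinase 2 (Homo sapiens), read by TR-FRET and LanthaScreen, with stated times of 50 min and 30 min, in the presence of a further agent that is not named here; a higher number here means a weaker inhibitor, a lower number a stronger inhibitor. Compound 2 stands lowest of the two numbers; its nearest neighbour is compound 1, whose value in this assay is 38 nM, a gap that lies beyond the usual scatter. Compound 1 is the more elaborated of the pair, and the bare core of compound 2 gives the lower number.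

Compound 3 `C[C@@H]1CCCN1c1c(C#N)c2c(N)nc(Nc3cn(C)nc3Cl)nc2n1C` has not yet been measured in this assay. It differs from compound 2 by (3-chloro-1-methyl-1H-pyrazol-4-yl)amino in place of hydrogen on an aromatic carbon. Going by the values given here, no direct step from one measured compound to another is available to calibrate this change, so the expectation rests on the two values shown: the larger compound 1 gives a higher number than compound 2, which suggests that elaboration at this core may cost rather than gain potency. The step of a 1.7-fold higher number from compound 2 to compound 3 (0.22 log units; within the scatter) is therefore expected to be a modest rise, possibly no larger than the scatter. Compound 3 is estimated at 25 nM, within a range of 8 nM to 80 nM.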

Compound 3, half-maximal inhibitory concentration: 34 nM
Beside the measured number, compound 3's estimate is 1.4-fold (0.13 log units) below it, within the range that was stated.
By their numbers in this assay, from the lowest: compound 2; then compounds 3 and 1 (each within the scatter of the next).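

In this assay, (3-chloro-1-methyl-1H-pyrazol-4-yl)amino in place of hydrogen, on the aromatic carbon between two ring nitrogen atoms, gives a 2.3-fold higher number from compound 2 to compound 3 (0.36 log units; beyond the scatter); this direct reading, which the earlier pair could not give, shows that the group modestly weakens inhibition on this core. 3-Chloro-1-methyl-1H-pyrazol-4-yl in place of 3-methyl-1-(oxetan-3-yl)-1H-pyrazol-4-yl on the nitrogen gives a 1.1-fold lower number from compound 1 to compound 3 (0.05 log units; within the scatter), so the two pyrazolyl groups cannot be told apart in this assay, and the substituents that differ between them make no difference that can be read here. Nothing is available to explain the step from hydrogen to the pyrazolylamino group.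

The compounds shown leave open whether a plain amine or a methoxy group on this aromatic carbon would give a number closer to that of compound 2 or one closer to that of compound 3. They also leave open whether a hydrogen, a fluorine or a methoxy group in place of the chlorine on the pyrazole of compound 3 would change the number beyond the scatter.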